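Sulfonamide nitrogen variation in a thioureido series

The source may report more compounds than this note shows. Statements on the series, on what has been measured and on what is new or still open speak of the compounds shown alone.

Measured so far in a functional assay on MDA-MB-231 cells (Homo sapiens) for antiproliferative activity, read by sulforhodamine B assay, with a stated time of 48 h; a lower number here means a stronger inhibitor, a higher number a weaker inhibitor:
compound 1, `CC(=O)NS(=O)(=O)c1ccc(N/C(S)=N\c2ccnc3cc(C(F)(F)F)ccc23)cc1`: 58600 nM
compound 2, `O=S(=O)(Nc1nccs1)c1ccc(N/C(S)=N\c2ccnc3cc(C(F)(F)F)ccc23)cc1`: 24400 nM
compound 3, `O=S(=O)(Nc1ccccn1)c1ccc(N/C(S)=N\c2ccnc3cc(C(F)(F)F)ccc23)cc1`: 49300 nM

All three share the same core and differ only in the group on the sulfonamide nitrogen. Compound 3 has the second highest of the three numbers; its number and that of compound 1 lie within the scatter of each other, so the order between them is not settled, while the step of a 2.0-fold higher number from compound 2 to compound 3 (0.31 log units; beyond the scatter) is beyond the scatter, and the step of a 2.4-fold lower number from compound 1 to compound 2 (0.38 log units; beyond the scatter) is of similar size.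

Compound 4, `O=S(=O)(Nc1ncccn1)c1ccc(N/C(S)=N\c2ccnc3cc(C(F)(F)F)ccc23)cc1`, is not yet measured in this assay. The change from compound 3 is pyrimidin-2-yl in place of pyridin-2-yl on a sulfonamide nitrogen. Going by the values given here, no measured step covers exactly this exchange of one aromatic ring for another of the same size; the nearest guide is a 2.0-fold higher number from compound 2 to compound 3 (0.31 log units; beyond the scatter), where a different heteroaryl with two hetero atoms gave a modestly lower number than the pyridin-2-yl. The change a 1.2-fold lower number from compound 1 to compound 3 (0.08 log units; within the scatter) shows that the pyridin-2-yl sits close to the acetyl.

On this basis a small downward step a 1.2-fold lower number from compound 3 to compound 4 (0.09 log units; within the scatter) is expected, not clearly beyond the scatter. Compound 4 is estimated at 40000 nM, within 18000 nM to 90000 nM.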

Compound 4, half-maximal inhibitory concentration: 45200 nM
Compound 4: the middle estimate sits 1.1-fold (0.05 log units) below what was measured; the measured number falls inside the stated range.
By their numbers in this assay, from the lowest: compounds 2, 4, 3 and 1 (each within the scatter of the next, the first and the last beyond it).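

In this assay, pyrimidin-2-yl in place of pyridin-2-yl on a sulfonamide nitrogen gives a step within the scatter (a 1.1-fold lower number from compound 3 to compound 4 (0.04 log units; within the scatter)), so adding a second hetero atom to this six-membered aromatic ring produces no readable change at this position. Compound 4 also lies within the scatter of both groups that are separated from each other beyond the scatter (a 1.9-fold higher number from compound 2 to compound 4 (0.27 log units; within the scatter); a 1.3-fold lower number from compound 1 to compound 4 (0.11 log units; within the scatter); compare a 2.4-fold lower number from compound 1 to compound 2 (0.38 log units; beyond the scatter)), so pyrimidin-2-yl does not distinguish between the 1,3-thiazol-2-yl and acetyl ends of this small set. No supporting measurement is available to explain the flat result at this position.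

All four groups leave the series in a narrow, weak band, from compound 2 at 24400 nM to compound 1 at 58600 nM, and the compounds shown do not tell whether any replacement on this nitrogen can move the number much further. A simple methyl, a carboxylic acid on a short chain, a longer chain ending in an amine or a phenyl ring in this place remains an open comparison.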